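A few compounds are considered here, and "the series" means these few. Any claim that something is new, unique, unknown or untested is made for them only; others in the source may bear on it.

Compound 1 `COc1cc(NC(C)CCCNC(=O)/C(C)=C/c2ccccc2)c2ncccc2c1` gives > 100 ug/mL in an ADME assay on L6 cells (Rattus norvegicus) for cytotoxicity, read by resazurin assay, with a stated time of 70 h (a lower number here means a stronger inhibitor, a higher number a weaker inhibitor), which is a limit of the assay rather than a number.
Compound 2 `COc1cc(NC(C)CCCNC(=O)/C=C/c2ccc(OC)c(OC)c2)c2ncccc2c1` gives > 100 ug/mL in this assay, again a limit.
Compound 3 `COc1cc(NC(C)CCCNC(=O)/C=C/c2cc(OC)c(OC)c(OC)c2)c2ncccc2c1` gives > 100 ug/mL in this assay, also a limit.

Compound 2 thus stands at a limit, and every value in this set does the same, as the limit of > 100 ug/mL in this assay, at which 3 of the 3 values shown sit, shows. Among the compounds with values here, the single step between measured compounds, a step that the two limits leave unreadable from compound 2 to compound 3, is consequently of unreadable size. Compound 4 `COc1cc(NC(C)CCCNC(=O)/C=C/c2ccccc2F)c2ncccc2c1` differs from compound 2 by 2-fluorophenyl in place of 3,4-dimethoxyphenyl on a double-bonded chain carbon bound to a double-bonded chain carbon. Within the data shown here, no measured step bears on that exchange, and the one step available carries no readable size. Compound 4 is therefore expected to remain at the limit, with an estimate of 150 ug/mL (60 ug/mL to 400 ug/mL). The expected step that the limit leaves unreadable from compound 2 to compound 4 lies within the scatter.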

Compound 4, half-maximal inhibitory concentration: 1.5 ug/mL
Compound 4: the middle estimate sits 100-fold (2.00 log units) above what was measured; the whole stated range lies above it.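

Replacing 3,4-dimethoxyphenyl with 2-fluorophenyl on a double-bonded chain carbon bound to a double-bonded chain carbon gives an at least 66-fold lower number from compound 2 to compound 4 (1.82 log units; beyond the scatter), so in this assay this position can carry a large change. Replacing 1-methyl-2-phenylethenyl with 2-(2-fluorophenyl)ethenyl on a carbonyl carbon gives an at least 66-fold lower number from compound 1 to compound 4 (1.82 log units; beyond the scatter), which points the same way. Compound 4 is the only compound here with a value that is a number and not a limit: the limit of > 100 ug/mL in this assay, at which 3 of the 4 values shown sit.

The compounds shown leave open whether the fluorine or the loss of the methoxy groups carries the step. From the compounds shown here alone, how a 2-chlorophenyl or 2-aminophenyl group would read in the same place also remains open.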